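The source may report more compounds than this note shows. Statements on the series, on what has been measured and on what is new or still open speak of the compounds shown alone.

Measured so far:
compound 1 `O=C(c1ccc(F)c(F)c1)N1CC(c2nc(-c3cccc(F)c3)no2)C1` — 3200 nM
compound 2 `Cc1ccc(S(=O)(=O)N2CC(c3nc(-c4cccc(Cl)c4)no3)C2)cc1` — > 10000 nM
compound 3 `Cc1cccc(-c2noc(C3CN(S(=O)(=O)c4ccc(F)cc4)C3)n2)c1` — > 10000 nM

For the measured compounds named here, in an assay on HEK293 cells for positive allosteric modulation of metabotropic glutamate receptor 5 (Homo sapiens), read by FLIPR (on this read-out lower numbers stand for an effect already at smaller amounts and higher numbers for an effect only at larger amounts of compound), compound 1 gives 3200 nM, the only number in the set. Compound 2 stops at the limit of the assay, > 10000 nM. Compound 3 likewise reports only the limit, > 10000 nM. Two of three values thus sit at the limit of > 10000 nM in this assay, at which 2 of the 3 values shown sit. Going by the values given here, no pair of measured compounds differs in a single place, so no measured step can be drawn, and compound 1 stands as the sole anchor.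

Compound 4 `Cc1ccc(C(=O)N2CC(c3nc(-c4cccc(F)c4)no3)C2)cc1` keeps the core of compound 1 with the change (4-methylphenyl in place of 3,4-difluorophenyl on a carbonyl carbon). The step expected is small, near the scatter, if anything towards larger amounts. Compound 4 is estimated at 5000 nM, range 1500 nM to 15000 nM. This estimate means an expected step of a 1.6-fold higher number from compound 1 to compound 4 (0.19 log units; within the scatter).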

Compound 4, half-maximal effective concentration: 6800 nM
Estimate against measurement, compound 4: 1.4-fold (0.13 log units) below, and the stated range covers the measured number.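

In this assay, for the compounds shown here, the change to 4-methylphenyl in place of 3,4-difluorophenyl gives a 2.1-fold higher number from compound 1 to compound 4 (0.33 log units; beyond the scatter) as the first readable step at this position on a carbonyl carbon. The position therefore responds to this change, modestly, and both aryl amides still return a number rather than a limit. Any further rise from compound 4 would have little readable range left: the limit of > 10000 nM in this assay, at which 2 of the 4 values shown sit.

As far as these compounds go, because the change swaps both fluorines for one methyl, the contribution of each remains open. Also open, from the compounds shown here alone, is whether a dimethylamino group, a carboxylic acid or a longer alkyl chain here would lower the number.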